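A methoxy added to the core of compound 2

A few compounds are considered here, and "the series" means these few. Any claim that something is new, unique, unknown or untested is made for them only; others in the source may bear on it.

- compound 1 `COc1ccc(-c2c(Nc3ccc(C)c(O)c3)c3ccccc3oc2=O)cc1` (10200 nM)
- compound 2 `COc1ccc(-c2c(Nc3ccc(C)cc3)c3ccccc3oc2=O)cc1` (59400 nM)
- compound 3 `COc1ccc(-c2c(Nc3ccc(NC(C)=O)cc3)c3ccccc3oc2=O)cc1` (> 100000 nM as a limit of the assay)

In a functional assay on HepG2 cells (Homo sapiens) for antiproliferative activity, read by MTT assay, with a stated time of 48 h (on this read-out higher numbers stand for weaker inhibition and lower numbers for stronger inhibition), compound 2 at 59400 nM holds the higher of the two exact numbers. Compound 3 gives only a limit of the assay (> 100000 nM) and no exact number. Replacing the hydroxy of compound 1 with hydrogen gave a 5.8-fold higher number from compound 1 to compound 2 (0.77 log units; beyond the scatter) and this is the gap to the nearest exact value. Replacing methyl with acetamido gave an at least 1.6-fold higher number from compound 2 to compound 3 (0.22 log units; that floor lies within the scatter) and that floor does not separate the two compounds.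

Compound 4 `COc1ccc(-c2c(Nc3ccc(C)cc3)c3ccc(OC)cc3oc2=O)cc1` differs from compound 2 in one place (methoxy in place of hydrogen on an aromatic carbon) with methoxy in place of hydrogen on an aromatic carbon of the fused system. Neither single-group step above was made at this place, so they offer only a rough sense of size and no direction. The clearest guide remains a 5.8-fold higher number from compound 1 to compound 2 (0.77 log units; beyond the scatter) as a change of one group on an aromatic carbon. With no direction supported, no shift beyond the scatter is expected in this assay and the range must stay wide. The expected change is a 1.2-fold lower number from compound 2 to compound 4 (0.07 log units; within the scatter) in this estimate. Compound 4 is estimated at 50000 nM with a range of 18000 nM to 100000 nM expected.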

Compound 4, half-maximal inhibitory concentration: 74400 nM
Beside the measured number, compound 4's estimate is 1.5-fold (0.17 log units) below it; the measured number falls inside the stated range.
By their numbers in this assay, from the lowest: compound 1; then compounds 2 and 4 (each within the scatter of the next). At a limit, above all of these: compound 3.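

In this assay, methoxy in place of hydrogen on this aromatic carbon of the fused system gave a 1.3-fold higher number from compound 2 to compound 4 (0.10 log units; within the scatter), so the change cannot be told apart from repeat measurement. Going by these compounds alone, this is the first view of this part of the molecule, as the earlier steps all changed the ring carried on the nitrogen, and here the added group leaves the reading in place, unlike the hydroxy step between compound 1 and compound 2, which lies beyond the scatter. Exact readings in this series end not far above these two compounds, and compound 3 stands only at a limit: the limit of > 100000 nM in this assay, at which 1 of the 4 values shown sits.

On these data alone, one methoxy at one place does not settle what other groups would do there, so it remains open whether an amine, a carboxylic acid or a longer chain such as ethoxy on this carbon would move the number. As far as these compounds go, it is also open whether adding the hydroxy of compound 1 to compound 4 would bring the same drop in the number on the methoxy-bearing core.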